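The source may hold more compounds than are shown below. What is called first, only, known or untested is meant among the compounds shown, and "the series" means these compounds.

For the measured compounds named here, compound 2 `CNS(=O)(=O)CCn1c(=N)sc2cc(OC(F)(F)F)ccc21` is the only compound with a measured number here. In a functional assay on the whole organism with Rattus norvegicus as the target (on this read-out lower numbers stand for an effect already at smaller amounts and higher numbers for an effect only at larger amounts of compound), compound 2 gives 4 mg/kg. Compound 1 `N=c1sc2cc(OC(F)(F)F)ccc2n1Cc1ccccc1` gives > 10 mg/kg, which is a limit of the assay rather than a number. The one measured step, an at least 2.5-fold lower number from compound 1 to compound 2 (0.39 log units; beyond the scatter), rests on that limit, as shown by the limit of > 10 mg/kg in this assay, at which 1 of the 2 values shown sits. Compound 3 `N=c1sc2cc(OC(F)(F)F)ccc2n1CCS` differs from compound 2 by sulfanyl in place of methylsulfamoyl on a saturated chain carbon, two bonds along the chain from an aromatic nitrogen. Going by the values given here, no measured step covers this change, so compound 3 is expected to sit close to compound 2, with a 1.5-fold higher number from compound 2 to compound 3 (0.18 log units; within the scatter) as the estimated step and wide uncertainty. Compound 3 is therefore estimated at 6 mg/kg, between 2 mg/kg and 20 mg/kg.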

Compound 3, dose for half-maximal effect: 2 mg/kg
Beside the measured number, compound 3's estimate is 3.0-fold (0.48 log units) above it; the range from low to high includes it.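

In this assay, the exchange at this chain carbon reads a 2.0-fold lower number from compound 2 to compound 3 (0.30 log units; within the scatter), so the much smaller sulfanyl stands in for methylsulfamoyl with no change beyond the scatter. The second chain end also parts from the phenyl group, at an at least 5.0-fold lower number from compound 1 to compound 3 (0.69 log units; beyond the scatter). That step rests on a limit of the assay for compound 1, not a number: the limit of > 10 mg/kg in this assay, at which 1 of the 3 values shown sits.

The compounds shown leave open whether a hydroxyl, an amine or a carboxylic acid on the same saturated chain carbon would keep the number in this range. They also leave open what a longer chain would do.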